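Trimming the indazole substituent in a diaryl urea series

The source may hold more compounds than are shown below. What is called first, only, known or untested is meant among the compounds shown, and "the series" means these compounds.

Among the measured compounds shown here, compound 2, `Cc1cccc2c1cnn2-c1ccc(NC(=O)Nc2ccc(Cl)c(C(F)(F)F)c2)cc1`, is the only member of this set with a numerical value: in a functional assay on SGC-7901 cells (Homo sapiens) for cytotoxicity, read by MTT assay, with a stated time of 72 h (a higher number here means a weaker inhibitor, a lower number a stronger inhibitor), compound 2 gives 14200 nM. Compound 1, `O=C(Nc1ccc(-n2ncc3c(C(F)(F)F)cccc32)cc1)Nc1ccc(Cl)c(C(F)(F)F)c1`, gives in this assay only a limit, > 32000 nM, as noted in the limit of > 32000 nM in this assay, at which 1 of the 2 values shown sits. For the measured compounds named here, the one measured step, an at least 2.2-fold lower number from compound 1 to compound 2 (0.35 log units; beyond the scatter), therefore rests on a limit at one end and is known only as a lower bound. Compound 3, `O=C(Nc1ccc(-n2ncc3ccccc32)cc1)Nc1ccc(Cl)c(C(F)(F)F)c1`, continues in the same direction: hydrogen in place of methyl on an aromatic carbon. Going by the values given here, no measured step follows that exact change; the step from compound 1 to compound 2 is the only related one and shows that shrinking this substituent did not raise the number. Compound 3 is accordingly expected to stay close to compound 2, with a step of a 1.2-fold lower number from compound 2 to compound 3 (0.07 log units; within the scatter) in this assay. The estimate for compound 3 in this assay is 12000 nM, with a range from 4500 nM to 32000 nM.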

Compound 3, half-maximal inhibitory concentration: > 32000 nM
Compound 3: only a limit was reported; the forecaster's own chance of this, stated with the estimate: 25%; middle value at least 2.6-fold (0.42 log units) from the limit.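

Going from methyl to hydrogen on this aromatic carbon does not extend the trend of the earlier step from trifluoromethyl to methyl, but reverses it: in this assay, the change gives an at least 2.2-fold higher number from compound 2 to compound 3 (0.35 log units; beyond the scatter). Compound 3 gives only a limit, > 32000 nM. Of the three substituents shown at this place, only methyl gives a numerical value, so a smaller group here does not simply mean a lower number, and the step between the trifluoromethyl and hydrogen compounds cannot be read: the limit of > 32000 nM in this assay, at which 2 of the 3 values shown sit.

On these data alone, how far compound 1 and compound 3 lie beyond that limit remains open, so the size of the loss on removing the methyl is known only as a lower bound. Also open, as far as these compounds go, is whether an ethyl chain, a methoxy group or an amine on this carbon would give a lower number than methyl in this assay.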